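The source may hold more compounds than are shown below. What is called first, only, known or untested is meant among the compounds shown, and "the series" means these compounds.

Among the compounds with values here, in a functional assay on PC-12 cells (Rattus norvegicus) for antiproliferative activity, read by resazurin assay, with a stated time of 24 h (a lower number here means a stronger inhibitor, a higher number a weaker inhibitor), the series holds only one plain number. Within the data shown here, compound 3 `CCCCCCCCc1ccc(/C=C/C(=O)[C@H](CO)NC(C)=O)cc1` gives 70000 nM and is the sole compound with a measured figure. Compound 2 `CCCCCCCCCCCCC/C=C/C(=O)[C@H](CO)NC(C)=O` shows > 200000 nM as a limit of the assay and not a number. For compound 1 `CC(=O)N[C@@H](CO)[C@H](O)/C=C/c1ccc(-c2ccccc2)cc1` the entry reads no result reported. No measured step links any of these compounds, so nothing calibrates the size of a single structural change.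

The next compound is compound 4 `CC(=O)N[C@@H](CO)C(=O)/C=C/c1ccccc1`. Its difference from compound 3 is hydrogen in place of octyl on an aromatic carbon with hydrogen in place of octyl on an aromatic carbon, para to a large group. A move toward weaker inhibition in this assay is expected rather than a gain, but compound 3 at 70000 nM is already weak, which leaves little room. The estimated step of a 2.1-fold higher number from compound 3 to compound 4 (0.33 log units; beyond the scatter) is expected to be modest, and a report of only a limit is quite possible. For compound 4 the expected value is 150000 nM with an estimated range from 70000 nM to 300000 nM if a number is reported at all.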

Compound 4, half-maximal inhibitory concentration: 42000 nM
For compound 4 the middle estimate is 3.6-fold (0.55 log units) above the measured one; measured number outside the range, below it.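

In this assay, within the data shown here, the only measured step is a 1.7-fold lower number from compound 3 to compound 4 (0.22 log units; within the scatter), with hydrogen in place of octyl on an aromatic carbon, para to a large group. This gives the series its first calibration: the whole octyl group can leave this position without the number moving past the scatter, so this one change gives no sign that octyl is needed here for the activity seen. No measured property on hand bears on this step.

On these data alone, whether another group at this position, such as an amine, a carboxylic acid or a chain longer than octyl, would move the number beyond the scatter stays open. A single step also leaves open whether the same replacement would behave alike on any other core.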